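A few compounds are considered here, and "the series" means these few. Any claim that something is new, unique, unknown or untested is made for them only; others in the source may bear on it.

Compound 3, `Cc1nn(C)c(Oc2ccc(F)c(F)c2)c1/C=N\CCCCCCOc1cc2oc(=O)cc(C)c2cc1Cl`, is one of three measured compounds built on the shared core. In a functional assay on SMMC-7721 cells (Homo sapiens) for antiproliferative activity, read by MTT assay, with a stated time of 72 h (on this read-out lower numbers stand for stronger inhibition and higher numbers for weaker inhibition), compound 1, `Cc1nn(C)c(Oc2cccc(F)c2)c1/C=N\CCCCCCOc1cc2oc(=O)cc(C)c2cc1Cl`, gives 23600 nM, and compound 2, `Cc1nn(C)c(Oc2ccc(F)cc2)c1/C=N\CCCCCCOc1cc2oc(=O)cc(C)c2cc1Cl`, gives 13500 nM. For compound 3 this assay returns only a limit, > 25000 nM, so compound 3 stands at the limit of the assay (the limit of > 25000 nM in this assay, at which 1 of the 3 values shown sits). Compound 4, `Cc1nn(C)c(Oc2ccccc2Br)c1/C=N\CCCCCCOc1cc2oc(=O)cc(C)c2cc1Cl`, differs from compound 3 by 2-bromophenyl in place of 3,4-difluorophenyl on an oxygen on an aromatic ring. The measured steps each move or add a fluorine: a 1.7-fold lower number from compound 1 to compound 2 (0.24 log units; within the scatter), an at least 1.0-fold higher number from compound 1 to compound 3 (0.02 log units; that floor lies within the scatter) and an at least 1.8-fold higher number from compound 2 to compound 3 (0.26 log units; that floor lies within the scatter), none beyond the scatter. A bromine entering in a new place is not covered by those steps, so no shift beyond the scatter is expected. The expected step is an at least 1.2-fold lower number from compound 3 to compound 4 (0.09 log units; that floor lies within the scatter). Compound 4 is therefore estimated at 20000 nM, in a range from 7000 nM to 60000 nM.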

Compound 4, half-maximal inhibitory concentration: 19700 nM
Estimate against measurement, compound 4: 1.0-fold (0.01 log units) above, within the range that was stated.
By their numbers in this assay, from the lowest: compounds 2, 4 and 1 (each within the scatter of the next). At a limit, above all of these: compound 3.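

In this assay, 2-bromophenyl on the oxygen stays within the scatter of both 3-fluorophenyl and 4-fluorophenyl, with a 1.5-fold higher number from compound 2 to compound 4 (0.16 log units; within the scatter) and a 1.2-fold lower number from compound 1 to compound 4 (0.08 log units; within the scatter), so a bromine at this position brings no shift beyond the scatter. Against the 3,4-difluorophenyl of compound 3, only a floor can be read: an at least 1.2-fold lower number from compound 3 to compound 4 (0.10 log units; that floor lies within the scatter). Compound 3 itself remains at a limit: the limit of > 25000 nM in this assay, at which 1 of the 4 values shown sits.

The compounds shown carry only halogens on this phenyl, so how an amine or a methoxy group would read here stays open. Going by these compounds, whether a shorter or longer chain would change these numbers also stays open.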